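This account rests on a few compounds, and the source may have more. Where it says the series, first, only, none or still open, it means among the compounds named here.

In a functional assay for inhibition, with Rattus norvegicus as the target (on this read-out higher numbers stand for weaker inhibition and lower numbers for stronger inhibition), two compounds sharing one core have been measured, and compound 2 `C[C@@H](/N=c1\c(O)c(O)\c1=N/c1ccc(C#N)cc1Cl)C(C)(C)C` holds the lower number of the pair. Compound 2 gives 41 nM, whereas compound 1 `CCCc1cc(C#N)ccc1/N=c1\c(O)c(O)\c1=N/[C@H](C)C(C)(C)C` gives 23100 nM. The open question concerns compound 3 `C[C@@H](/N=c1\c(O)c(O)\c1=N/c1ccc(C#N)cc1C(=O)c1ccccc1)C(C)(C)C`, which has not yet been measured. It carries benzoyl in place of chloro on an aromatic carbon, and the counted difference is benzoyl in place of chloro on an aromatic carbon.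

Among the measured compounds shown here, only one measured step bears on this change, and it concerns the same aromatic carbon. With chloro in place of propyl, the data show a 560-fold lower number from compound 1 to compound 2 (2.75 log units; beyond the scatter), a large step. Read in reverse, this step links the loss of chloro to a much higher number. For the measured compounds named here, the comparison is loose, since no measured compound has a ring or a carbonyl at this carbon. A substantial step towards a higher number is therefore expected in this assay, probably smaller than the one measured, though with wide uncertainty. The expected change is a 20-fold higher number from compound 2 to compound 3 (1.29 log units; beyond the scatter). For compound 3, the estimate is 800 nM, with an expected range of 120 nM to 6000 nM.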

Compound 3, half-maximal inhibitory concentration: 4780 nM
Compound 3: the middle estimate sits 6.0-fold (0.78 log units) below what was measured; the measured number falls inside the stated range.
By their numbers in this assay, from the lowest: compound 2; then compound 3; then compound 1.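

In this assay the move from chloro to benzoyl gives a 120-fold higher number from compound 2 to compound 3 (2.07 log units; beyond the scatter), which shows that the low number of compound 2 does not survive a second, quite different replacement at this carbon, ortho to a large group and meta to a cyano group. Benzoyl brings a six-membered aromatic ring and a hydrogen-bond acceptor that propyl lacks, yet the change from propyl to benzoyl gives only a 4.8-fold lower number from compound 1 to compound 3 (0.68 log units; beyond the scatter) and leaves compound 3 much nearer to compound 1 than to compound 2 on the logarithmic scale, so chloro remains the only group among these three with a number in the low range. No accompanying evidence accounts for these steps.

The compounds shown leave open whether fluoro, bromo or methyl at this carbon would keep a number close to that of compound 2, and so whether the sharp rise begins with any group other than chloro. They also leave open how the ring and the carbonyl of benzoyl each contribute, which a phenyl or an acetyl group at the same carbon could separate.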